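Cytotoxicity series: compound 2 to compound 4 in the amide substituent

A few compounds are considered here, and "the series" means these few. Any claim that something is new, unique, unknown or untested is made for them only; others in the source may bear on it.

In an ADME assay on HepG2 2.2.15 cells (Homo sapiens) for cytotoxicity, read by MTT assay, with stated times of 48 h and 9 days (on this read-out lower numbers stand for higher toxicity in this test and higher numbers for lower toxicity in this test), the three measured compounds fall close together. Compound 1 `COc1ccc(CNC(=O)/C=C/c2coc3cc(O)ccc3c2=O)cc1` gives 718000 nM, compound 3 `O=C(/C=C/c1coc2cc(O)ccc2c1=O)Nc1ccccc1` gives 821000 nM, and compound 2 `COc1cccc(NC(=O)/C=C/c2coc3cc(OC)ccc3c2=O)c1` gives 1130000 nM. All three numbers lie within the scatter of one another, so nothing separates compound 2 from compound 1 or compound 3 in this assay. For the measured compounds named here, no single-point step between measured compounds is available. Compound 4 `COc1ccc2c(=O)c(/C=C/C(=O)NCc3ccc(F)cc3F)coc2c1` is not yet measured; it differs from compound 2 by 2,4-difluorobenzyl in place of 3-methoxyphenyl on an amide-type nitrogen. On these data no step beyond the scatter is expected from compound 2 to compound 4, and the estimated step is a 1.3-fold lower number from compound 2 to compound 4 (0.10 log units; within the scatter). Compound 4 is expected to give about 900000 nM, with a range from 400000 nM to 2000000 nM.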

Compound 4, half-maximal cytotoxic concentration: 79300 nM
Compound 4: the middle estimate sits 11-fold (1.05 log units) above what was measured; measured number below the stated range.
By their numbers in this assay, from the lowest: compound 4; then compounds 1, 3 and 2 (each within the scatter of the next).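

In this assay the amide-type nitrogen proves able to move the number: 2,4-difluorobenzyl in place of 3-methoxyphenyl gives a 14-fold lower number from compound 2 to compound 4 (1.15 log units; beyond the scatter) and this is the only step beyond the scatter among the compounds shown. The earlier compounds shown here, all within the scatter of one another, gave no sign of this. Nothing measured here bears on the reason for the step.

As far as these compounds go, whether the step belongs to the two fluorines or to the benzyl link remains open. Plain benzyl or 2,4-difluorophenyl on the same nitrogen would separate the two.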